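Swapping a sulfur-linked heterocycle for an ethylpiperazine

The compounds below may be only part of what the source reports. "The series", "measured", "known", "first", "only" and "open" are said of these compounds alone.

Measured compounds in a functional assay on MCF7 cells (Homo sapiens) for cytotoxicity, read by MTT assay, with a stated time of 24 h, tested at 0.64 ug/mL; on this read-out lower numbers stand for a weaker effect and higher numbers for a stronger effect at the one concentration tested:
- compound 1 `Cc1ccc2oc(SCC(=O)Nc3ccc(-c4nc(-c5ccccc5)c(-c5ccccc5)n4C)cc3)nc2c1` gives 1.1%
- compound 2 `Cn1c(-c2ccc(NC(=O)CSc3nc4ccccc4s3)cc2)nc(-c2ccccc2)c1-c1ccccc1` gives 0.9%
- compound 3 `CN1CCN(CC(=O)Nc2ccc(-c3nc(-c4ccccc4)c(-c4ccccc4)n3C)cc2)CC1` gives 1.1%

All three numbers sit close together, and each of the steps between them lies within the scatter of the method: a number 0.2 percentage points lower from compound 1 to compound 2 (within the scatter), no change at the digits printed from compound 1 to compound 3 (within the scatter) and a number 0.2 percentage points higher from compound 2 to compound 3 (within the scatter). Compound 2 therefore stands among values that cannot be told apart from its own; none of the three compounds shows a clear effect at the concentration tested.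

Compound 4 `CCN1CCN(CC(=O)Nc2ccc(-c3nc(-c4ccccc4)c(-c4ccccc4)n3C)cc2)CC1` has not yet been measured. It differs from compound 2 in one place: 4-ethylpiperazin-1-yl in place of (1,3-benzothiazol-2-yl)sulfanyl on a saturated chain carbon bound to a carbonyl carbon. The step from compound 2 to compound 3 is the closest guide: there a piperazine also entered where the sulfur-linked heterocycle left, and that step a number 0.2 percentage points higher from compound 2 to compound 3 (within the scatter) stayed within the scatter. No larger change is expected from compound 2 to compound 4 in this assay: a number 0.1 percentage points higher from compound 2 to compound 4 (within the scatter) is the estimated step. The expected value for compound 4 is 1%, with a likely range from 0% to 8%.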

Compound 4, a percentage reported as activity, at one concentration (the size of the read-out at that concentration, not a potency): 4.7%
Estimate against measurement, compound 4: 3.7 percentage points below; the measured number falls inside the stated range.
By their numbers in this assay, from the lowest: compounds 2, 1, 3 and 4 (each within the scatter of the next).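

In this assay, the 4-ethylpiperazin-1-yl group on a saturated chain carbon bound to a carbonyl carbon cannot be told apart from either sulfur-linked heterocycle, with a number 3.8 percentage points higher from compound 2 to compound 4 (within the scatter) and a number 3.6 percentage points higher from compound 1 to compound 4 (within the scatter) as the steps. Extending the piperazine substituent by one carbon, methyl in place of hydrogen on a saturated chain carbon bound to an amine nitrogen in a ring, likewise gives a number 3.6 percentage points higher from compound 3 to compound 4 (within the scatter) and so does not separate the two piperazines. Nothing available explains any of these numbers.

Going by these compounds, whether a different group at this place, such as a morpholine, a carboxylic acid or a propyl chain on the piperazine, would give a step beyond the scatter remains open. On these data alone, with one concentration, it also remains open how these compounds would compare at other concentrations.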